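This account rests on a few compounds, and the source may have more. Where it says the series, first, only, none or still open, it means among the compounds named here.

Measured so far in a functional assay, read by spectrophotometry, with a stated time of 30 min; on this read-out higher numbers stand for weaker inhibition and lower numbers for stronger inhibition:

- compound 1 `O=c1[nH]c2ccccc2cc1/C=N/CCO`: "not active" (no number reported), no number reported
- compound 2 `N/N=C/c1cc2ccccc2[nH]c1=O`: 729000 nM
- compound 3 `CCCC/N=C/c1cc2ccccc2[nH]c1=O`: 439000 nM

Compound 3 holds the lowest of the two numbers in this assay; its nearest neighbour is compound 2, and the step of a 1.7-fold lower number from compound 2 to compound 3 (0.22 log units; within the scatter) lies within the scatter, so the two are not separable. Compound 1 contributes no number at all.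

Compound 4 `O=c1[nH]c2ccccc2cc1/C=N/Cc1ccccc1` is not yet measured. Relative to compound 3 the change is phenyl in place of propyl on a saturated chain carbon bound to a double-bonded nitrogen. Among the measured compounds shown here, the only measured step, from compound 2 to compound 3, concerns the group on the double-bonded nitrogen and is within the scatter; no measured pair exchanges propyl for phenyl on the chain carbon, so nothing here bears directly on the change to compound 4. With no step beyond the scatter anywhere in the series, no shift beyond the scatter is expected in this assay, in either direction.

Compound 4 is therefore estimated near the value of compound 3, at 420000 nM, with a range of 150000 nM to 1200000 nM; the step of a 1.0-fold lower number from compound 3 to compound 4 (0.02 log units; within the scatter) is expected to stay within the scatter. Given that compound 1 gave no number, some chance remains that compound 4 also returns no number.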

Compound 4, half-maximal inhibitory concentration: "not active" (no number reported)
No number was reported for compound 4, and the estimate cannot be compared.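

In this assay compound 4 gives "not active" (no number reported) and so, with no number to set against compound 3, no step can be read. Nothing shown bears on the reason for this result. The compounds shown leave open how far phenyl in place of propyl shifts inhibition, and in which direction.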